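A few compounds are considered here, and "the series" means these few. Any claim that something is new, unique, unknown or untested is made for them only; others in the source may bear on it.

Measured in a physicochemical assay for lipophilicity; a higher number here means a more lipophilic compound, a lower number a more polar compound:
- Compound 1 `O=C1/C(=C/c2ccccc2)CCC/C1=C\c1cccc([N+](=O)[O-])c1`: 4.9
- Compound 2 `O=C1/C(=C/c2ccc(F)cc2)CCC/C1=C\c1cccc([N+](=O)[O-])c1`: 5.07
- Compound 3 `O=C1/C(=C/c2ccc(F)cc2)CCC/C1=C\c1ccc([N+](=O)[O-])cc1`: 5.09

In this assay compound 3 gives 5.09, and all three values lie within the scatter of one another. Compound 4 `COc1ccc(/C=C2\CCC/C(=C\c3ccc([N+](=O)[O-])cc3)C2=O)cc1` differs from compound 3 by methoxy in place of fluoro on an aromatic carbon, with methoxy in place of fluoro on an aromatic carbon. For the measured compounds named here, no measured step introduces methoxy. The nearest evidence is a number 0.17 log units higher from compound 1 to compound 2 (within the scatter), a case of fluoro in place of hydrogen on an aromatic carbon. That evidence is only indirect, but it suggests a small change. The expected step is a number 0.09 log units lower from compound 3 to compound 4 (within the scatter), which is not expected to go beyond the scatter in either direction. The estimate for compound 4 is 5, with an expected range from 4.7 to 5.3.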

Compound 4, partition coefficient: 4.98
Beside the measured number, compound 4's estimate is 0.02 log units above it; the range from low to high includes it.
By their numbers in this assay, from the lowest: compounds 1, 4, 2 and 3 (each within the scatter of the next).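

In this assay, methoxy in place of fluoro on an aromatic carbon gives a number 0.11 log units lower from compound 3 to compound 4 (within the scatter). For the compounds shown here, this is the first measured step with methoxy at this position, and although methoxy counts a hydrogen-bond acceptor and fluoro none, the read-out stays within the scatter. Nothing measured here explains why these two groups read so alike. Still open, as far as these compounds go, is whether an amine or a carboxylic acid at this same position would also stay within the scatter, and whether methoxy would do so elsewhere on the shared core.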